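A few compounds are considered here, and "the series" means these few. Any claim that something is new, unique, unknown or untested is made for them only; others in the source may bear on it.

Measured in an ADME assay on BJ cells (Homo sapiens) for cytotoxicity, with a stated time of 72 h; on this read-out higher numbers stand for an effect only at larger amounts of compound and lower numbers for an effect already at smaller amounts:
- Compound 1 `C=C[C@@](C)(/C=C/c1ccc(O)cc1)CCC=O`: > 36600 nM, a limit.
- Compound 2 `C=C[C@@](C)(/C=C/c1ccc(O)c(/C=C/C#N)c1)CCC=C(C)C`: > 36600 nM, a limit.
- Compound 3 `COc1ccc(/C=C/[C@@](C)(/C=C/c2ccc(O)c(C=O)c2)CCC=C(C)C)cc1`: 9800 nM.

Among the measured compounds shown here, compound 3 is the only compound with a number. The other two stand at the limit of > 36600 nM in this assay, at which 2 of the 3 values shown sit.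

Compound 4 `COc1ccc(/C=C/[C@@](C)(/C=C/c2ccc(O)c(/C=C/C#N)c2)CCC=C(C)C)cc1` differs from compound 3 by 2-cyanoethenyl in place of formyl on an aromatic carbon, ortho to a hydroxy group. For the measured compounds named here, no measured step covers this change. Compound 2 also carries 2-cyanoethenyl and gives > 36600 nM, which is a limit, so a modest move towards higher numbers is expected in this assay. The estimated step is a 1.4-fold higher number from compound 3 to compound 4 (0.15 log units; within the scatter). For compound 4 the estimated value is 14000 nM, with an expected range of 6000 nM to 33000 nM.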

Compound 4, half-maximal effective concentration: > 23700 nM
Compound 4 ended at the assay's limit; the forecaster's own chance of this, stated with the estimate: 25%; middle value at least 1.6-fold (0.22 log units) from the limit.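

Replacing formyl with 2-cyanoethenyl on the aromatic carbon ortho to a hydroxy group gives, in this assay, an at least 2.4-fold higher number from compound 3 to compound 4 (0.38 log units; beyond the scatter). Among the compounds shown here, this is the first readable step at this position, and only its lower bound is known: the limit of > 23700 nM in this assay, at which 1 of the 4 values shown sits. The step between compound 2 and compound 4 cannot be read, since both values are limits.

On these data alone, how far compound 4 lies beyond its limit remains open. Also open, as far as these compounds go, is whether an amine or a carboxylic acid at this position would give a lower or a higher number than formyl.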